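Dichlorophenyl replaces ethynylphenyl on a thienopyrimidine-free shared core

The source may report more compounds than this note shows. Statements on the series, on what has been measured and on what is new or still open speak of the compounds shown alone.

Measured compounds:
compound 1 `C#Cc1cccc(Nc2ncnc3sc(NC(=O)/C=C/c4ccccc4)cc23)c1`, 5050 nM
compound 2 `N#Cc1cccc(Nc2ncnc3cc(NC(=O)/C=C/c4ccccc4)sc23)c1`, 1040 nM
compound 3 `COc1ccc(/C=C/C(=O)Nc2cc3ncnc(Nc4ccc(F)c(Cl)c4)c3s2)cc1`, 2600 nM

In a functional assay on MDA-MB-231 cells (Homo sapiens) for antiproliferative activity, read by MTT assay, with a stated time of 48 h (a higher number here means a weaker inhibitor, a lower number a stronger inhibitor), compound 1 gives the highest of the three numbers. Its gap to compound 3 lies within the scatter, while its gap to compound 2 lies beyond it. Compound 4 `O=C(/C=C/c1ccccc1)Nc1cc2c(Nc3ccc(Cl)c(Cl)c3)ncnc2s1` is not yet measured. The change from compound 1 to compound 4 is 3,4-dichlorophenyl in place of 3-ethynylphenyl on a nitrogen on an aromatic ring. Among the compounds with values here, no measured pair isolates this change; compound 3, carrying a different halogenated ring and a different cinnamide, gives 2600 nM. For compound 4 a modest lowering of the number is expected, a 1.9-fold lower number from compound 1 to compound 4 (0.29 log units; within the scatter), probably not beyond the scatter. The estimate for compound 4 in this assay is 2600 nM, with a range from 1000 nM to 6500 nM.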

Compound 4, half-maximal inhibitory concentration: 4400 nM
The estimate for compound 4 lay 1.7-fold (0.23 log units) below the measured number; the measured number falls inside the stated range.
By their numbers in this assay, from the lowest: compound 2; then compounds 3, 4 and 1 (each within the scatter of the next).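

In this assay, 3,4-dichlorophenyl in place of 3-ethynylphenyl on a nitrogen on an aromatic ring gives a 1.1-fold lower number from compound 1 to compound 4 (0.06 log units; within the scatter), the first step shown that isolates a single change. At this position on the shared core, the two chlorines thus stand in for the triple bond with no change beyond the scatter. Nothing available explains this result. From the compounds shown here alone, whether an amine or a carboxylic acid on this phenyl ring would shift the number remains open. So does whether the 3,4-dichlorophenyl result holds with a different group on the cinnamide.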